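Bromo in place of chloro and toxicity on liver cells

This account rests on a few compounds, and the source may have more. Where it says the series, first, only, none or still open, it means among the compounds named here.

Compound 1 `O=c1cc(CNCc2ccccc2Cl)oc2ccc(O)c(O)c12`: > 100000 nM
Compound 2 `O=c1cc(CNCc2ccccc2Br)oc2ccc(O)c(O)c12`: > 100000 nM
Compound 3 `O=c1cc(CNCc2ccc(Cl)cc2)oc2ccc(O)c(O)c12`: > 100000 nM

All three compounds were tested in an ADME assay on Huh-7 cells (Homo sapiens) for cytotoxicity; on this read-out higher numbers stand for lower toxicity in this test and lower numbers for higher toxicity in this test. Compound 1 reaches only the limit of the assay, > 100000 nM. Compound 2 likewise gives only a limit, > 100000 nM. Compound 3 also gives only a limit, > 100000 nM. The change from compound 1 to compound 2 is bromo in place of chloro on an aromatic carbon and gives a step that the two limits leave unreadable from compound 1 to compound 2, which is unreadable because of the limit of > 100000 nM in this assay, at which 3 of the 3 values shown sit. The cores of compound 1 and compound 3 differ by 4-chlorophenyl in place of 2-chlorophenyl on a saturated chain carbon bound to an amine nitrogen. Compound 4 `O=c1cc(CNCc2ccc(Br)cc2)oc2ccc(O)c(O)c12` is not yet measured; it differs from compound 3 by bromo in place of chloro on an aromatic carbon. Within the data shown here, this is the same kind of change as the one from compound 1 to compound 2, but there the place was ortho to a large group, whereas here it is para to a large group. For compound 4 in this assay a step that the limit leaves unreadable from compound 3 to compound 4 is expected, resting on compound 3 sitting at > 100000 nM and on (the limit of > 100000 nM in this assay, at which 3 of the 3 values shown sit). Compound 4 is therefore estimated at 150000 nM, between 80000 nM and 400000 nM.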

Compound 4, half-maximal cytotoxic concentration: > 100000 nM
Compound 4: no number, only a limit; the forecaster's own chance of this, stated with the estimate: 85%; the middle value lies beyond the limit too.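

In this assay, among these compounds, compound 4 gives only a limit, so no step between it and compound 1, compound 2 or compound 3 can be read, because all the compounds sit at the same limit: the limit of > 100000 nM in this assay, at which 4 of the 4 values shown sit. The compounds shown leave open whether bromo in place of chloro, or 4-chlorophenyl in place of 2-chlorophenyl, makes any difference in this assay.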